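Benzyl ether series: methyl to chloro on the outer ring

This account rests on a few compounds, and the source may have more. Where it says the series, first, only, none or still open, it means among the compounds named here.

For the measured compounds named here, compound 2 `Cc1ccc(COc2ccc(-c3nn(CCC#N)c(=S)o3)cc2)cc1` holds the lowest of the two numbers so far in an assay for inhibition of Amine oxidase [flavin-containing] B (Rattus norvegicus); a higher number here means a weaker inhibitor, a lower number a stronger inhibitor; in it compound 2 gives 400 nM. Going by the values given here, compound 1 `COc1ccc(COc2ccc(-c3nn(CCC#N)c(=S)o3)cc2)cc1` gives 910 nM in this assay, and the single step measured so far, a 2.3-fold lower number from compound 1 to compound 2 (0.36 log units; beyond the scatter), came from methyl in place of methoxy on an aromatic carbon. Compound 3 `N#CCCn1nc(-c2ccc(OCc3ccc(Cl)cc3)cc2)oc1=S` differs from compound 2 by chloro in place of methyl on an aromatic carbon. Among the compounds with values here, no measured step exchanges methyl for chloro, so the direction cannot be read from the data; the one step available, a 2.3-fold lower number from compound 1 to compound 2 (0.36 log units; beyond the scatter), shows only that a change of the group on this ring moves the number modestly. A step of similar size in either direction, or none beyond the scatter, is expected. Compound 3 is therefore estimated at 300 nM, with a range from 100 nM to 900 nM, an expected step of a 1.3-fold lower number from compound 2 to compound 3 (0.12 log units; within the scatter).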

Compound 3, half-maximal inhibitory concentration: 690 nM
Beside the measured number, compound 3's estimate is 2.3-fold (0.36 log units) below it; the measured number falls inside the stated range.
By their numbers in this assay, from the lowest: compounds 2, 3 and 1 (each within the scatter of the next, the first and the last beyond it).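

On the outer ring, para to a large group, chloro in place of methyl gives a 1.7-fold higher number from compound 2 to compound 3 (0.24 log units; within the scatter) in this assay, while chloro in place of methoxy gives a 1.3-fold lower number from compound 1 to compound 3 (0.12 log units; within the scatter) in the same assay. Both steps lie within the scatter, so chloro cannot be told apart from either methyl or methoxy here, even though those two are separated by a 2.3-fold lower number from compound 1 to compound 2 (0.36 log units; beyond the scatter) and that step lies beyond it. This place therefore tolerates all three groups with only modest movement in the number, and chloro does not extend the spread set by the first two compounds.

Open, as far as these compounds go, is whether an amine, a carboxylic acid or a longer chain at this place would move the number further, and whether a second substituent on the same ring would do so. No supporting data bear on the reasons for these numbers.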